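Cyclic amine variation on the thiocarbonyl carbon: working notes

The source may hold more compounds than are shown below. What is called first, only, known or untested is meant among the compounds shown, and "the series" means these compounds.

Measured so far:
- compound 1 `N/C(=N\NC(=S)N1CCN(c2ccccn2)CC1)c1ccc(F)cn1` — 2000 nM
- compound 2 `N/C(=N\NC(=S)N1CCCC1)c1ccc(F)cn1` — 1800 nM

In a functional assay on HeLa cells (Homo sapiens) for cytotoxicity, read by MTT assay, with a stated time of 72 h (a lower number here means a stronger inhibitor, a higher number a weaker inhibitor), compound 1 gives 2000 nM and compound 2 gives 1800 nM. Compound 2 has the lowest of the two numbers, but its gap to compound 1 lies within the scatter of this assay, so the two cannot be told apart; neither counts as the stronger. The two share the same core and differ only in the cyclic amine on the thiocarbonyl carbon, and that exchange leaves the number essentially where it was.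

Compound 3 `N/C(=N\NC(=S)N1CCSCC1)c1ccc(F)cn1` has not yet been run in this assay. It differs from compound 2 by thiomorpholin-4-yl in place of pyrrolidin-1-yl on a thiocarbonyl carbon. Within the data shown here, no measured pair covers exactly this change. Among the measured compounds shown here, the only comparison available, compound 1 against compound 2, shows two different cyclic amines at the same position giving numbers within the scatter. The step from compound 2 to compound 3 is therefore expected to be small, with no direction beyond the scatter: a 1.1-fold higher number from compound 2 to compound 3 (0.02 log units; within the scatter). Compound 3 is estimated at 1900 nM, with a range from 900 nM to 4000 nM.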

Compound 3, half-maximal inhibitory concentration: 1700 nM
Beside the measured number, compound 3's estimate is 1.1-fold (0.05 log units) above it; the measured number falls inside the stated range.
By their numbers in this assay, from the lowest: compounds 3, 2 and 1 (each within the scatter of the next).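

In this assay, thiomorpholin-4-yl in place of pyrrolidin-1-yl on a thiocarbonyl carbon gives a 1.1-fold lower number from compound 2 to compound 3 (0.02 log units; within the scatter), the first step printed for this position, and it lies within the scatter. This single exchange swaps a five-membered non-aromatic ring with no hydrogen-bond acceptor for a six-membered one holding a sulfur and a hydrogen-bond acceptor, yet those differences in ring and count do not separate the two compounds in this read-out; with the piperazine-type amine of compound 1 also in the ranking, each of the three compounds falls within the scatter of the next, so none can be called the strongest. No measurement at hand bears on why the number holds across these exchanges.

Still open, from the compounds shown here alone, is whether an open-chain amine such as diethylamino, or a cyclic amine carrying a carboxylic acid, on the thiocarbonyl carbon would move the number beyond the scatter. Going by these compounds, all three compounds also keep the fluorine on the shared core, so it remains open whether the same insensitivity to the cyclic amine would hold with a hydrogen or a chlorine in its place.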